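The source may hold more compounds than are shown below. What is called first, only, known or untested is meant among the compounds shown, and "the series" means these compounds.

In a functional assay on NCI-H460 cells (Homo sapiens) for antiproliferative activity, read by CCK-8 assay, with a stated time of 72 h (on this read-out higher numbers stand for weaker inhibition and lower numbers for stronger inhibition), two compounds have been measured.
Compound 1 `CCC(C)n1cnc2c(NCc3ccc(C(=O)Nc4ccccc4N)cc3)nc(Cl)nc21` gives 4940 nM
Compound 2 `CC(C)n1cnc2c(NCc3ccc(C(=O)Nc4ccccc4N)cc3)nc(Cl)nc21` gives 3410 nM

Compound 2 lies within the scatter of compound 1, so the two cannot be told apart. Compound 3 `Nc1ccccc1NC(=O)c1ccc(CNc2nc(Cl)nc3c2ncn3C2CCCC2)cc1` differs from compound 2 in one place, with cyclopentyl in place of isopropyl on an aromatic nitrogen. Among the measured compounds shown here, only one measured step bears on this, the hydrogen in place of methyl in a 1.4-fold lower number from compound 1 to compound 2 (0.16 log units; within the scatter) which stays within the scatter. For the measured compounds named here, no measured compound carries a ring at that place, so this guide is thin. No step beyond the scatter is expected in this assay for this change. The estimated step is a 1.1-fold lower number from compound 2 to compound 3 (0.06 log units; within the scatter) in size. Compound 3 is expected at 3000 nM with an estimated range from 1200 nM to 7500 nM in this read-out.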

Compound 3, half-maximal inhibitory concentration: 5780 nM
Compound 3: middle estimate off by 1.9-fold (0.28 log units), on the low side; measured number inside the range.
By their numbers in this assay, from the lowest: compounds 2, 1 and 3 (each within the scatter of the next).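

The first ring on the aromatic nitrogen leaves the number in this assay within the scatter of both open-chain groups: cyclopentyl in place of isopropyl gives (a 1.7-fold higher number from compound 2 to compound 3 (0.23 log units; within the scatter)), and cyclopentyl in place of sec-butyl gives (a 1.2-fold higher number from compound 1 to compound 3 (0.07 log units; within the scatter)). Across sec-butyl, isopropyl and cyclopentyl, then, this place shows no step beyond the scatter, whether or not the group holds a ring. No evidence on why is available for this result. Going by these compounds, whether a phenyl ring, a cyclohexyl ring or a chain ending in an amine on this nitrogen would move the number beyond the scatter remains open.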